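The source may hold more compounds than are shown below. What is called first, only, known or untested is meant among the compounds shown, and "the series" means these compounds.

Measured compounds and their values:
- compound 1 `CCCC(=O)N1CCC(c2cc(OC)ccc2N)=N1`, 13.1%
- compound 2 `COc1ccc(N)c(C2=NN(C(=O)C3CC3)CC2)c1`, 19.9%
- compound 3 `COc1ccc(N)c(C2=NN(C(=O)c3ccccc3)CC2)c1`, 12.2%

All three share one core and differ only in the group on the carbonyl carbon. In an assay on isolated protein for inhibition of Nitric oxide synthase, inducible (Homo sapiens), with a stated time of 30 min, tested at 1 mM (on this read-out lower numbers stand for less inhibition and higher numbers for more inhibition at the one concentration tested (going by the name of the read-out)), compound 2 gives the highest of the three numbers, yet the step of a number 6.8 percentage points higher from compound 1 to compound 2 (within the scatter) and the step of a number 7.7 percentage points lower from compound 2 to compound 3 (within the scatter) both lie within the scatter, so the three compounds cannot be told apart on these numbers.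

Compound 4 `COc1cc(N)c(C2=NN(C(=O)C3CC3)CC2)cc1OC` is not yet measured. It differs from compound 2 by one change: methoxy in place of hydrogen on an aromatic carbon.

Among the compounds with values here, none of the measured steps touches the aromatic ring; every one of them swaps the group on the carbonyl carbon, and each of those swaps stayed within the scatter of this assay. Within the data shown here, there is therefore no measured step that bears directly on this change, and the whole series sits in a narrow, low band of inhibition. The expectation for compound 4 is a step of a number 0.1 percentage points higher from compound 2 to compound 4 (within the scatter) that stays within the scatter. Compound 4 is estimated at 20%, within a range from 5% to 38%.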

Compound 4, a percentage reported as inhibition, at one concentration (the size of the read-out at that concentration, not a potency): 25.2%
The estimate for compound 4 lay 5.2 percentage points below the measured number, and the stated range covers the measured number.
By their numbers in this assay, from the lowest: compounds 3, 1, 2 and 4 (each within the scatter of the next, the first and the last beyond it).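

Within the data shown here, this is the first measured change on the aromatic ring rather than on the carbonyl carbon, and in this assay it reads as a number 5.3 percentage points higher from compound 2 to compound 4 (within the scatter), a step that stays within the scatter. A methoxy group can therefore stand on this aromatic carbon, ortho to a methoxy group and para to a large group, without the read-out shifting beyond what repeated measurements would show. No measurement shown here points to a cause for this step.

As far as these compounds go, it stays open whether another group at this position, such as a fluorine atom, a hydroxyl group or a longer ethoxy chain, would move the number beyond the scatter. From the compounds shown here alone, it also stays open whether replacing the amino group on the same ring with a hydroxyl group would change the number.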